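Moving the chlorine around the aryl ring of a piperazine series

This account rests on a few compounds, and the source may have more. Where it says the series, first, only, none or still open, it means among the compounds named here.

The three measured compounds share one core and differ only in the aryl group on the piperazine. Compound 1 `O=c1oc2cccnc2n1CN1CCN(c2ccccc2)CC1` gives 11% in a functional assay on the whole organism for inhibition, with Rattus norvegicus as the target, read by paw edema, at a dose of 50 mg/kg; on this read-out higher numbers stand for more inhibition at the one dose given (going by the name of the read-out) and lower numbers for less inhibition. Compound 2 `O=c1oc2cccnc2n1CN1CCN(c2cccc(Cl)c2)CC1` gives 27% in this assay, and compound 3 `COc1ccccc1N1CCN(Cn2c(=O)oc3cccnc32)CC1` gives 15% in this assay. Compound 3 thus stands second of three: its number and that of compound 1 lie within the scatter of each other, while compound 2 sits beyond it, a number 12 percentage points lower from compound 2 to compound 3 (beyond the scatter).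

Compound 4 `O=c1oc2cccnc2n1CN1CCN(c2ccc(Cl)cc2)CC1` is not yet measured. Its change from compound 3 is 4-chlorophenyl in place of 2-methoxyphenyl on an amine nitrogen in a ring. Among the measured compounds shown here, two measured steps bear on this. Adding a chlorine gave a number 16 percentage points higher from compound 1 to compound 2 (beyond the scatter), and replacing the chlorophenyl by the methoxyphenyl gave a number 12 percentage points lower from compound 2 to compound 3 (beyond the scatter). Compound 4 brings a chlorophenyl back, though with the chlorine at a different ring position, and no 4-chlorophenyl has been measured here. A modest rise is therefore expected, a number 9 percentage points higher from compound 3 to compound 4 (within the scatter). Compound 4 is estimated at 24%, within a range of 10% to 40%.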

Compound 4, a percentage reported as inhibition, in the whole organism at one dose (the size of the read-out at that dose, not a potency): 23%
Compound 4: middle estimate off by 1 percentage points, on the high side; low and high end bracket the measured number.
By their numbers in this assay, from the lowest: compounds 1, 3, 4 and 2 (each within the scatter of the next, the first and the last beyond it).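

In this assay the result shows that the rise seen with chlorine on the phenyl ring is not tied to the 3-chlorophenyl alone: the 4-chlorophenyl gives a number 12 percentage points higher from compound 1 to compound 4 (beyond the scatter) and so also stands clear of the unsubstituted phenyl. The two chlorine positions cannot be told apart, with a number 4 percentage points lower from compound 2 to compound 4 (within the scatter) as the whole difference, and the 4-chlorophenyl is not separated from the 2-methoxyphenyl either, with a number 8 percentage points higher from compound 3 to compound 4 (within the scatter) on that step, although the 3-chlorophenyl was. Nothing available explains these numbers or says what the chlorine does at this place.

On these data alone, whether a fluoro or a nitrile in place of the chlorine would stand with the chlorophenyl compounds remains open. So does whether a benzyl group on the ring nitrogen would keep the read-out at this level.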